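The source may hold more compounds than are shown below. What is called first, only, known or untested is meant among the compounds shown, and "the series" means these compounds.

Compound 1 `O=C(/C=C\Nc1ccc(C(F)(F)F)cc1)c1cn(-c2ccccc2)nc1-c1ccc(F)cc1` and compound 2 `COc1ccc(-c2nn(-c3ccccc3)cc2C(=O)/C=C\Nc2ccc(C(F)(F)F)cc2)cc1` share one core and differ at a single aromatic carbon, where compound 2 carries methoxy in place of fluoro. In a functional assay on HT-29 cells (Homo sapiens) for antiproliferative activity, read by MTT assay, with a stated time of 48 h (on this read-out higher numbers stand for weaker inhibition and lower numbers for stronger inhibition), compound 1 gives > 50000 nM, a limit of the assay rather than a number, namely (the limit of > 50000 nM in this assay, at which 1 of the 2 values shown sits). In this assay compound 2 gives 9870 nM. Within the data shown here, of the two values shown, that of compound 2 is the only number. Among the measured compounds shown here, the step of an at least 5.0-fold lower number from compound 1 to compound 2 (0.70 log units; beyond the scatter) is the single measured step that bears on what follows. Compound 3 `COc1cc(-c2nn(-c3ccccc3)cc2C(=O)/C=C\Nc2ccc(C(F)(F)F)cc2)cc(OC)c1OC` has not been measured in this assay; it differs from compound 2 by 3,4,5-trimethoxyphenyl in place of 4-methoxyphenyl on an aromatic carbon. For the measured compounds named here, the one measured step moved toward lower numbers when a methoxy entered, and the change to compound 3 brings two further methoxy groups onto that phenyl, so a further move toward lower numbers is expected, the expected step being a 2.5-fold lower number from compound 2 to compound 3 (0.39 log units; beyond the scatter). Compound 3 is therefore estimated at 4000 nM, with a range from 800 nM to 20000 nM.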

Compound 3, half-maximal inhibitory concentration: > 50000 nM
Compound 3: no number, only a limit; the forecaster's own chance of this, stated with the estimate: 10%; at least 12-fold (1.09 log units) between middle value and limit.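

At this position, on the aromatic carbon of the five-membered ring, adding methoxy groups did not extend the earlier trend: in this assay, 3,4,5-trimethoxyphenyl in place of 4-methoxyphenyl reversed it, giving an at least 5.0-fold higher number from compound 2 to compound 3 (0.70 log units; beyond the scatter). The result for compound 3 is a limit of the assay and not a number, and it is the same limit as the one seen earlier: the limit of > 50000 nM in this assay, at which 2 of the 3 values shown sit. The step from compound 1 to compound 3 cannot be read, as both values are limits.

From the compounds shown here alone, how far the number rises with 3,4,5-trimethoxyphenyl therefore stays open, as does whether one added methoxy would already reverse the step. Also open, going by these compounds, is whether a hydroxyl, an amine or an ethoxy group on that phenyl would behave as methoxy does.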